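Thiosemicarbazone series: methyl at the hydrazone carbon

A few compounds are considered here, and "the series" means these few. Any claim that something is new, unique, unknown or untested is made for them only; others in the source may bear on it.

Measured compounds:
compound 1, `CC1=CC[C@@H]([C@@](C)(O)CCCC(C)(C)NC=S)CC1`: in a functional assay on K562 cells (Homo sapiens) for cytotoxicity, read by sulforhodamine B assay (on this read-out higher numbers stand for weaker inhibition of growth and lower numbers for stronger inhibition of growth), compound 1 gives > 100000 nM, which is a limit of the assay, not a number.
compound 2, `CC1=CC[C@@H]([C@@](C)(O)CCCC(C)(C)NC(=S)N/N=C\c2ccccc2)CC1`: compound 2 gives 20900 nM.
compound 3, `CC1=CC[C@@H]([C@@](C)(O)CCCC(C)(C)NC(=S)N/N=C\c2ccc(O)cc2)CC1`: compound 3 gives 31100 nM.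

Compound 2 holds the lowest of the two numbers; the nearest is compound 3, reached by a 1.5-fold higher number from compound 2 to compound 3 (0.17 log units; within the scatter), so the two cannot be ordered. For the measured compounds named here, the only step beyond the scatter is an at least 4.7-fold lower number from compound 1 to compound 2 (0.67 log units; beyond the scatter), where the whole hydrazone fragment enters on the thiocarbonyl carbon; its size is a lower bound because of the limit of > 100000 nM in this assay, at which 1 of the 3 values shown sits.

Compound 4, `CC1=CC[C@@H]([C@@](C)(O)CCCC(C)(C)NC(=S)N/N=C(/C)c2ccccc2)CC1`, differs from compound 2 by a group of 9 heavy atoms (8 carbon, 1 nitrogen; one six-membered aromatic ring of carbon only) in place of a group of 8 heavy atoms (7 carbon, 1 nitrogen; one six-membered aromatic ring of carbon only), on an amide-type nitrogen. The measured steps bear on it only loosely: the step from compound 1 to compound 2 shows that the hydrazone fragment matters, while the step from compound 2 to compound 3 shows that a change on its aromatic ring stayed within the scatter. A single added carbon on the hydrazone carbon is therefore expected to produce no step beyond the scatter in this assay. Compound 4 is estimated at 21000 nM, within 8000 nM to 55000 nM. The expected change from compound 2 is thus a 1.0-fold higher number from compound 2 to compound 4 (0.00 log units; within the scatter).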

Compound 4, concentration for total growth inhibition: 70 nM
Compound 4: the middle estimate sits 300-fold (2.48 log units) above what was measured; measured number outside the range, below it.
By their numbers in this assay, from the lowest: compound 4; then compounds 2 and 3 (each within the scatter of the next). At a limit, above all of these: compound 1.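

Replacing the group of 8 heavy atoms on the amide-type nitrogen with the group of 9 heavy atoms gives a 300-fold lower number from compound 2 to compound 4 (2.48 log units; beyond the scatter) in this assay, so this place in the hydrazone fragment can carry a large step, whereas the hydroxy change on the aromatic ring gave only a 1.5-fold higher number from compound 2 to compound 3 (0.17 log units; within the scatter), within the scatter. Measured against the hydroxy compound, the same result appears as a 440-fold lower number from compound 3 to compound 4 (2.65 log units; beyond the scatter), although that pair also differs on the aromatic ring, so this step does not isolate the methyl group at the hydrazone carbon. The compounds shown offer no measurement that explains why so small a change in the group has so large an effect in this assay.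

On these data alone, it remains open whether the effect is specific to methyl or would persist with ethyl, a longer chain, or trifluoromethyl at the hydrazone carbon. As far as these compounds go, it also remains open how far the result of compound 4 would hold with a hydroxy, an amine or a carboxylic acid on its aromatic ring, and whether it extends beyond this assay.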